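Bromo step carried from compound 1 over to compound 3

The compounds below may be only part of what the source reports. "The series", "measured", "known", "first", "only" and "open" are said of these compounds alone.

Compound 1 `COc1cc(/C(Cl)=C/C=C(\C#N)C(=O)c2c[nH]c3ccccc23)cc(OC)c1OC` gives 59.1% in a functional assay for inhibition, with a stated time of 5 min, tested at 1 mM; on this read-out lower numbers stand for less inhibition and higher numbers for more inhibition at the one concentration tested (going by the name of the read-out). Compound 2 `COc1cc(/C(Cl)=C/C=C(\C#N)C(=O)c2c[nH]c3ccc(Br)cc23)cc(OC)c1OC` carries the change bromo in place of hydrogen on an aromatic carbon and gives 50% in this assay; the step of a number 9.1 percentage points lower from compound 1 to compound 2 (within the scatter). Compound 3 `COc1ccc(/C(Cl)=C/C=C(\C#N)C(=O)c2c[nH]c3ccccc23)cc1OC` differs from compound 1 in its core by hydrogen in place of methoxy on an aromatic carbon. In this assay compound 3 gives 63.6%; the step of a number 4.5 percentage points higher from compound 1 to compound 3 (within the scatter). Among the compounds with values here, compound 3 thus gives 63.6% where compound 2 gives 50%, and no single step links those two.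

Compound 4 `COc1ccc(/C(Cl)=C/C=C(\C#N)C(=O)c2c[nH]c3ccc(Br)cc23)cc1OC` has not been measured. Within the data shown here, it differs from compound 3 by bromo in place of hydrogen on an aromatic carbon, which is the same change as the one from compound 1 to compound 2, at the same place. Among the measured compounds shown here, the only measured example of this change is the step of a number 9.1 percentage points lower from compound 1 to compound 2 (within the scatter), within the scatter. On that basis the step from compound 3 to compound 4 is expected to be about a number 9.1 percentage points lower from compound 3 to compound 4 (within the scatter), of the same size as that earlier one, and rests on that single pair alone. Compound 4 is therefore estimated at 54.5% in this assay, with a range from 40% to 68%.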

Compound 4, a percentage reported as inhibition, at one concentration (the size of the read-out at that concentration, not a potency): 80.9%
For compound 4 the middle estimate is 26.4 percentage points below the measured one; measured number above the stated range.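

In this assay the bromo change does not carry over from one core to the other, with a number 17.3 percentage points higher from compound 3 to compound 4 (beyond the scatter) set against the earlier step: the same change on two cores in this assay, a number 9.1 percentage points lower (within the scatter) from compound 1 to compound 2 and a number 17.3 percentage points higher (beyond the scatter) from compound 3 to compound 4, 26.4 percentage points apart, beyond the scatter of two such steps.
The change from methoxy to hydrogen likewise depends on its partner, with a number 30.9 percentage points higher from compound 2 to compound 4 (beyond the scatter) set against its earlier step: the same change on two cores in this assay, a number 4.5 percentage points higher (within the scatter) from compound 1 to compound 3 and a number 30.9 percentage points higher (beyond the scatter) from compound 2 to compound 4, 26.4 percentage points apart, beyond the scatter of two such steps.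
The two changes therefore do not add up independently across these four compounds at the one concentration tested, but this single set of four gives no general rule for other cores, does not explain the gap, and says nothing about potency.

As far as these compounds go, whether a chloro, a methyl or an amine in place of the bromo would behave as on the core of compound 3 or as on the core of compound 1 remains open. Also open, from the compounds shown here alone, is whether a carboxylic acid in place of the nitrile would preserve the gap between these two cores.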